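This account rests on a few compounds, and the source may have more. Where it says the series, first, only, none or still open, it means among the compounds named here.

- compound 1 `C=CCCOc1cc(O)c2c(=O)c(OCCC=C)c(-c3ccc4c(c3)OC(c3ccc(OCCC=C)c(OC)c3)C(CO)O4)oc2c1` gives 79400 nM
- compound 2 `COc1cc(C2Oc3cc(-c4oc5cc(OCC=C(C)C)cc(O)c5c(=O)c4O)ccc3OC2CO)ccc1OCC=C(C)C` gives 47400 nM

In a functional assay on PC-12 cells (Rattus norvegicus), read by MTT assay, with stated times of 2 h and 4 h (on this read-out higher numbers stand for an effect only at larger amounts of compound and lower numbers for an effect already at smaller amounts), compound 1 gives 79400 nM and compound 2 gives 47400 nM so the two values lie within the usual scatter of each other, and neither can be ranked over the other. Compound 3 `C=CCCOc1cc(O)c2c(=O)c(O)c(-c3ccc4c(c3)OC(c3ccc(OCCC=C)c(OC)c3)C(CO)O4)oc2c1` differs from compound 1 in one place, where (but-3-en-1-yl)oxy becomes hydroxy. This puts hydrogen in place of but-3-en-1-yl on an oxygen on an aromatic ring and leaves the rest of the structure unchanged.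

Going by the values given here, no measured pair shows this change on its own, so there is no direct precedent for its size. With compound 1 at 79400 nM as the starting point, no step beyond the scatter is expected in this assay for this change. The estimated step is a 1.6-fold lower number from compound 1 to compound 3 (0.20 log units; within the scatter) on this read-out. For compound 3 the expected value is 50000 nM with an estimated range from 20000 nM to 120000 nM in this measurement.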

Compound 3, half-maximal effective concentration: 37700 nM
Compound 3: middle estimate off by 1.3-fold (0.12 log units), on the high side, and the stated range covers the measured number.
By their numbers in this assay, from the lowest: compounds 3, 2 and 1 (each within the scatter of the next, the first and the last beyond it).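

In this assay, exchanging (but-3-en-1-yl)oxy for hydroxy gives a 2.1-fold lower number from compound 1 to compound 3 (0.32 log units; beyond the scatter), a modest step that shows this position responds to the change. Removing the but-3-en-1-yl chain from this oxygen does not lose the effect; it appears at smaller amounts of compound. This is the first change in one place that can be read in this series, since compound 1 and compound 2 differ in more than one place, but nothing shown gives a cause for the step.

The compounds shown leave open how a methyl group or a longer chain on this oxygen would compare, and whether a chain ending in an amine or a carboxylic acid would read differently. They also leave open whether the same change at the other (but-3-en-1-yl)oxy groups of compound 3 would give a step of similar size.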